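Nitro-to-methyl exchange across two related cores

The source may hold more compounds than are shown below. What is called first, only, known or untested is meant among the compounds shown, and "the series" means these compounds.

Four compounds are compared in a functional assay on XF498 cells (Homo sapiens) for antiproliferative activity, read by MTT assay, with a stated time of 96 h; on this read-out higher numbers stand for weaker inhibition and lower numbers for stronger inhibition. Compound 1 `O=C1NN(c2ccc([N+](=O)[O-])cc2)C(=O)C2(CSC3=C2C(=O)c2ncccc2C3=O)N1` carries a 4-nitrophenyl group and gives 4800 nM in this assay. Compound 2 `Cc1ccc(N2NC(=O)NC3(CSC4=C3C(=O)c3ncccc3C4=O)C2=O)cc1` differs from it only by methyl in place of nitro on an aromatic carbon; in this assay compound 2 gives 3800 nM. The step of a 1.3-fold lower number from compound 1 to compound 2 (0.10 log units; within the scatter) is small, so the two values are not distinguished here.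

Compound 3 `O=C1C2=C(C(=O)c3ncccc31)C1(CS2)NC(=O)N(c2ccc([N+](=O)[O-])cc2)C1=O` is built on a different core; the difference between its core and the core of compound 1 is not broken down here. In this assay compound 3 gives 1030 nM, the lowest of the three measured numbers, and its separation from compound 2 and from compound 1 lies beyond the scatter.

Compound 4 `Cc1ccc(N2C(=O)NC3(CSC4=C3C(=O)c3ncccc3C4=O)C2=O)cc1` has not been measured. It differs from compound 3 by methyl in place of nitro on an aromatic carbon, the same change, at the same place, as that from compound 1 to compound 2. Because a 1.3-fold lower number from compound 1 to compound 2 (0.10 log units; within the scatter) stayed within the scatter on the first core, the expectation for compound 4 is a step of about a 1.2-fold lower number from compound 3 to compound 4 (0.08 log units; within the scatter), with the inhibitory concentration staying close to that of compound 3. Going by the values given here, compound 4 is accordingly estimated at 850 nM in this assay, within a range of 350 nM to 2100 nM that allows for the scatter and for the core being different from the one on which the exchange was measured. Whether the second core responds to the exchange as the first did is expected but not established by these three measurements.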

Compound 4, half-maximal inhibitory concentration: 1350 nM
Compound 4: middle estimate off by 1.6-fold (0.20 log units), on the low side, and the stated range covers the measured number.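

In this assay, the exchange of 4-nitrophenyl for 4-methylphenyl on the second core gives a 1.3-fold higher number from compound 3 to compound 4 (0.12 log units; within the scatter), so on this core, as on the first, the change leaves no readable difference. Set side by side, the two steps do not differ from each other: the same change on two cores in this assay, a 1.3-fold lower number (0.10 log units; within the scatter) from compound 1 to compound 2 and a 1.3-fold higher number (0.12 log units; within the scatter) from compound 3 to compound 4, 1.7-fold (0.22 log units) apart, within the scatter of two such steps. The exchange therefore carries over between these two cores as a change without a readable effect on this read-out, but two pairs in one cell line do not show that the cores respond identically, and they say nothing about any other core or any other assay.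

Going by these compounds, only nitro and methyl appear at this place on the aromatic ring, so it remains open whether an amine, a carboxylic acid or a longer alkyl chain on the same aromatic carbon would also leave the number within the scatter on either core. Also open is what in the core of compound 3 sets it apart from the core of compound 1, as no pair shown isolates a single part of that difference.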